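Lengthening the Hydroxamate Linker from Compound 3 to Compound 4

The source may hold more compounds than are shown below. What is called first, only, known or untested is meant among the compounds shown, and "the series" means these compounds.

Compound 3 `C#CCN(C)Cc1ccc(NC(=O)CCCC(=O)NO)cc1` reaches only the limit of a functional assay on PC-3 cells (Homo sapiens) for inhibition, read by MTT assay, with a stated time of 48 h; a higher number here means a weaker inhibitor of growth, a lower number a stronger inhibitor of growth: in this assay compound 3 gives > 10000 nM, a limit rather than a number. Compound 2 `C#CCN(C)Cc1ccc(NC(=O)CCC(=O)NO)cc1` likewise gives > 10000 nM, also a limit. The step that the two limits leave unreadable from compound 2 to compound 3 therefore cannot be read, since both values sit at the limit of > 10000 nM in this assay, at which 2 of the 3 values shown sit. Compound 1 `C#CCN(C)Cc1cccc(NC(=O)CCCCCCC(=O)NO)c1`, built differently in two places, gives 330 nM. Compound 4 `C#CCN(C)Cc1ccc(NC(=O)CCCCC(=O)NO)cc1` differs from compound 3 by (hydroxycarbamoyl)methyl in place of hydroxycarbamoyl on a saturated chain carbon, three bonds along the chain from a carbonyl carbon. Within the data shown here, no measured step of this kind is readable here, so compound 4 is expected to stay near the limit, with the step of an at least 1.2-fold lower number from compound 3 to compound 4 (0.09 log units; that floor lies within the scatter) estimated as small. Compound 4 is expected to give 8000 nM, within 2000 nM to 30000 nM.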

Compound 4, concentration for 50% growth inhibition: > 10000 nM
Compound 4 was reported as a limit; the forecaster's own chance of this, stated with the estimate: 50%; middle value at least 1.2-fold (0.09 log units) away from the limit.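

Compound 4 also sits at a limit in this assay, so the steps to it from compound 2 and compound 3 cannot be read: the limit of > 10000 nM in this assay, at which 3 of the 4 values shown sit.

The compounds shown leave open whether a longer chain on the core of compound 4 would give a measurable value.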